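The source may report more compounds than this note shows. Statements on the series, on what has been measured and on what is new or still open speak of the compounds shown alone.

Of the compounds shown here, three share one core and have been measured in a functional assay on the whole organism for inhibition, with Rattus norvegicus as the target, at a dose of 30 mg/kg; a higher number here means more inhibition at the dose given (going by the name of the read-out), a lower number less inhibition. Compound 1, `Cc1ccc(-c2nc3ncccc3o2)cc1`, gives 5%. Compound 2, `Clc1ccc(-c2nc3ncccc3o2)cc1`, gives 24%. Compound 3, `Fc1cccc(F)c1-c1nc2cccnc2o1`, gives 50%. Among these three numbers compound 2 stands second highest: compound 1 is nearest, with a number beyond the scatter lower, and compound 3 furthest, with a number beyond the scatter higher.

Going by the values given here, only one step between compounds that differ in a single place has been measured: a number 19 percentage points higher from compound 1 to compound 2 (beyond the scatter). That step is modest but beyond the scatter.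

Compound 4, `Fc1ccc(-c2nc3ncccc3o2)cc1`, has not yet been measured. It differs from compound 2 in one place: fluoro in place of chloro on an aromatic carbon. Among the compounds with values here, no measured pair shows what fluoro does in this position, so the one measured step can only be a loose guide. Both chloro in compound 2 and fluoro in compound 4 are single heavy atoms with no hydrogen-bond donors or acceptors, so the expectation is a small step, a number 9 percentage points lower from compound 2 to compound 4 (within the scatter), downward but within the scatter. For compound 4 the estimated value in this assay is 15%, with a range from 3% to 35%.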

Compound 4, a percentage reported as inhibition, in the whole organism at one dose (the size of the read-out at that dose, not a potency): 28%
Compound 4: the middle estimate sits 13 percentage points below what was measured; low and high end bracket the measured number.
By their numbers in this assay, from the lowest: compound 1; then compounds 2 and 4 (each within the scatter of the next); then compound 3.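

In this assay, fluoro in place of chloro on this aromatic carbon gives a step within the scatter (a number 4 percentage points higher from compound 2 to compound 4 (within the scatter)), so these compounds do not separate the two halogens at this position. Fluoro in place of methyl gives a step beyond the scatter (a number 23 percentage points higher from compound 1 to compound 4 (beyond the scatter)), just as chloro in place of methyl did (a number 19 percentage points higher from compound 1 to compound 2 (beyond the scatter)), so among these three compounds the measurable difference lies between methyl and either halogen, not between one halogen and the other. Nothing available here explains why these groups give the numbers they do.

On these data alone, with only methyl, chloro and fluoro compared at this position, it remains open whether the higher numbers seen with the two halogens extend to a bromo or a trifluoromethyl group, or whether a methoxy group, an amine, a carboxylic acid or a longer chain would give a quite different number. As far as these compounds go, it also remains open whether the same swaps would give the same steps elsewhere on this ring, since every comparison here rests on a single position at a single dose.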